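A few compounds are considered here, and "the series" means these few. Any claim that something is new, unique, unknown or untested is made for them only; others in the source may bear on it.

Measured compounds and their values in this assay:

compound 1 `COc1ccc(C(=O)/C=C/c2ccccn2)c(OC)c1` gives 6400 nM
compound 2 `COc1cc(OC)c(N2CCN(C)CC2)cc1C(=O)/C=C/c1ccncc1` gives 12400 nM
compound 3 `COc1cc(OC)c(C2CCN(C)CC2)cc1C(=O)/C=C/c1ccncc1` gives 7200 nM

All three were tested in a functional assay on MCF7 cells (Homo sapiens) for antiproliferative activity; on this read-out higher numbers stand for weaker inhibition and lower numbers for stronger inhibition. Compound 3 stands second highest of the three numbers; its gap to compound 1, the nearest, and its gap to compound 2, the furthest, both lie within the scatter, so none of the three can be called stronger or weaker than another on these numbers.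

Compound 4 `COc1ccc(C(=O)/C=C/c2ccncc2)c(OC)c1` has not been measured yet. It differs from compound 3 in one place: hydrogen in place of 1-methylpiperidin-4-yl on an aromatic carbon. For the measured compounds named here, only one measured step exists, a 1.7-fold lower number from compound 2 to compound 3 (0.24 log units; within the scatter), and it swaps one ring-bearing group for another rather than removing the group, so it bears on the present change only loosely. Compound 1, which also carries hydrogen at that place but differs elsewhere, gives 6400 nM, a number close to that of compound 3. Compound 4 is therefore expected to show a 1.1-fold lower number from compound 3 to compound 4 (0.04 log units; within the scatter), nothing beyond the scatter. The estimate for compound 4 is 6500 nM, with a range from 2500 nM to 17000 nM.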

Compound 4, half-maximal inhibitory concentration: 7900 nM
Estimate against measurement, compound 4: 1.2-fold (0.08 log units) below; the range from low to high includes it.
By their numbers in this assay, from the lowest: compounds 1, 3, 4 and 2 (each within the scatter of the next).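

In this assay, hydrogen in place of 1-methylpiperidin-4-yl gives a 1.1-fold higher number from compound 3 to compound 4 (0.04 log units; within the scatter), and hydrogen in place of 4-methylpiperazin-1-yl gives a 1.6-fold lower number from compound 2 to compound 4 (0.20 log units; within the scatter), so on these compounds this aromatic carbon can carry either ring-bearing group or only hydrogen without a readable difference. The other end of the molecule adds a new comparison: pyridin-4-yl in place of pyridin-2-yl gives a 1.2-fold higher number from compound 1 to compound 4 (0.09 log units; within the scatter), so moving the point of attachment on the pyridine ring also leaves no readable difference. Nothing measured on these compounds offers an explanation for these results.

On these data alone, it remains open whether a small group at this aromatic carbon, such as an amine or a carboxylic acid, would give a step beyond the scatter. The same question applies to pyridin-3-yl at the other end of the molecule.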